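A few compounds are considered here, and "the series" means these few. Any claim that something is new, unique, unknown or untested is made for them only; others in the source may bear on it.

Measured so far in a functional assay on PC-3 cells (Homo sapiens) for inhibition, read by MTT assay; on this read-out higher numbers stand for weaker inhibition and lower numbers for stronger inhibition:
compound 1, `Nc1nc(-c2ccc([N+](=O)[O-])cc2)cc(-c2cnn(-c3ccccc3)n2)n1` — > 200000 nM.
compound 2, `Nc1nc(-c2ccccc2)cc(-c2cccs2)n1` — 33600 nM.

Compound 1 gives > 200000 nM in this assay, which is a limit of the assay, not a number; this is the limit of > 200000 nM in this assay, at which 1 of the 2 values shown sits. Within the data shown here, compound 2 is therefore the only compound of the pair with a numeric half-maximal inhibitory concentration in this assay, where compound 2 gives 33600 nM, and it stands alone as the sole point of reference for the series.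

Compound 3, `Nc1nc(-c2ccccc2)cc(-c2ccc[nH]2)n1`, has not yet been measured in this assay. It differs from compound 2 in one place: 1H-pyrrol-2-yl in place of thiophen-2-yl on an aromatic carbon. Among the measured compounds shown here, no measured step between two compounds that differ in one place exists in this set, so there is no reference for the size of such a swap. Given only compound 2 at 33600 nM, the step from compound 2 to compound 3 is expected to stay within the usual scatter, in no particular direction: a 1.0-fold higher number from compound 2 to compound 3 (0.02 log units; within the scatter). Compound 3 is accordingly estimated at 35000 nM in this assay, with a likely range from 12000 nM to 100000 nM.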

Compound 3, half-maximal inhibitory concentration: 81600 nM
For compound 3 the middle estimate is 2.3-fold (0.37 log units) below the measured one, within the range that was stated.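

In this assay, among these compounds, the first one-place comparison gives a 2.4-fold higher number from compound 2 to compound 3 (0.39 log units; beyond the scatter). The aromatic carbon next to the ring nitrogen of the shared core therefore does not treat these two five-membered aromatic rings as interchangeable, although the step is modest and the direction favours thiophen-2-yl on this read-out. The two groups match at 5 heavy atoms and differ in the hetero atom, sulfur against nitrogen, and in their counts, with 1 hydrogen-bond donor and 0 hydrogen-bond acceptors for 1H-pyrrol-2-yl against 0 and 1 for thiophen-2-yl, but nothing measured here connects the step to any of these differences.

Still open, on these data alone, is how the same position responds to furan-2-yl, which would keep the ring size with oxygen as the hetero atom, or to 1-methyl-1H-pyrrol-2-yl, which would replace the pyrrole hydrogen with a methyl group. A single step also leaves open whether the same swap gives a step of similar size when the phenyl group on the core carries a substituent such as a methoxy group or a chlorine.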